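The compounds below may be only part of what the source reports. "The series", "measured", "known", "first", "only" and "open" are said of these compounds alone.

Measured so far:
compound 1 `CN(C)C(=O)c1cccnc1NCCCN1CCN(c2ccccc2)CC1` — 15.9 nM
compound 2 `CN(C)C(=O)c1cccnc1NCCCN1CCN(c2ccccc2-c2ccccc2)CC1` — 63.1 nM
compound 3 `CN(C)C(=O)c1cccnc1NCCCN1CCN(c2ccccc2C2CC2)CC1` — 63.1 nM

In a functional assay on aorta for antagonist activity at Alpha-1D adrenergic receptor (Rattus norvegicus) (on this read-out lower numbers stand for tighter binding and higher numbers for weaker binding), compound 1 gives 15.9 nM and compound 3 gives 63.1 nM. Compound 3 stands level with compound 2 and the two together carry the highest numbers of the three: no change at the digits printed from compound 2 to compound 3 (within the scatter). Against compound 1 the difference is clearer, a 4.0-fold higher number from compound 1 to compound 3 (0.60 log units; beyond the scatter), matching a 4.0-fold higher number from compound 1 to compound 2 (0.60 log units; beyond the scatter) for the other substituted member.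

Compound 4 `CN(C)C(=O)c1cccnc1NCCCN1CCN(c2ccccc2C(F)(F)F)CC1` is the next member. Compared with compound 3 the change is trifluoromethyl in place of cyclopropyl on an aromatic carbon. The step that bears most directly on it is the earlier exchange of one group for another at the same position, no change at the digits printed from compound 2 to compound 3 (within the scatter), which was flat. The two steps from the unsubstituted compound 1, a 4.0-fold higher number from compound 1 to compound 2 (0.60 log units; beyond the scatter) and a 4.0-fold higher number from compound 1 to compound 3 (0.60 log units; beyond the scatter), show that occupying this position costs a modest amount, and compound 3 has already paid that. The expectation is therefore no step beyond the scatter: a 1.0-fold lower number from compound 3 to compound 4 (0.00 log units; within the scatter). Compound 4 is estimated at 63 nM, with a range from 25 nM to 160 nM.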

Compound 4, dissociation constant: 316 nM
For compound 4 the middle estimate is 5.0-fold (0.70 log units) below the measured one; measured number outside the range, above it.
By their numbers in this assay, from the lowest: compound 1; then compounds 2 and 3 (each within the scatter of the next); then compound 4.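

In this assay, the position no longer reads as a single cost of being occupied, since the identity of the group now matters: a 5.0-fold higher number from compound 3 to compound 4 (0.70 log units; beyond the scatter), and likewise a 5.0-fold higher number from compound 2 to compound 4 (0.70 log units; beyond the scatter), whereas phenyl and cyclopropyl had stood level. Measured from the unsubstituted parent, the full change is a 20-fold higher number from compound 1 to compound 4 (1.30 log units; beyond the scatter), so trifluoromethyl carries a clearly larger penalty here than either of the other two groups. No supporting measurement is available to explain this separation.

The compounds shown leave open whether a methyl group or a single chlorine at this position would stand with phenyl and cyclopropyl or with trifluoromethyl. Going by these compounds, it is equally open how an amine or a carboxylic acid in the same place would read in this assay.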